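The source may report more compounds than this note shows. Statements on the series, on what has been measured and on what is new or still open speak of the compounds shown alone.

Measured in a functional assay on HCT-15 cells (Homo sapiens) for antiproliferative activity, read by sulforhodamine B assay; on this read-out higher numbers stand for weaker inhibition of growth and lower numbers for stronger inhibition of growth:
- Compound 1 `CCCCCCOc1cccc(O)c1C(=O)/C=C/c1ccc(O)cc1`: > 30000 nM, a limit of the assay
- Compound 2 `CC(C)(C)CCOc1cccc(O)c1C(=O)/C=C/c1ccc(O)cc1`: 3430 nM
- Compound 3 `CC(C)CCOc1cccc(O)c1C(=O)/C=C/c1ccc(O)cc1`: 10600 nM

Of the two true numbers, compound 3 has the higher, at 10600 nM. Compound 4 `CCC(CC)COc1cccc(O)c1C(=O)/C=C/c1ccc(O)cc1` differs from it by pentan-3-yl in place of isobutyl on a saturated chain carbon bound to an oxygen on an aromatic ring, with pentan-3-yl in place of isobutyl on a saturated chain carbon bound to an oxygen on an aromatic ring.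

The steps of an at least 8.7-fold lower number from compound 1 to compound 2 (0.94 log units; beyond the scatter) and an at least 2.8-fold lower number from compound 1 to compound 3 (0.45 log units; beyond the scatter) both lie beyond the scatter, but each starts from a limit. Within the data shown here, the step of a 3.1-fold higher number from compound 2 to compound 3 (0.49 log units; beyond the scatter) is the only one between two true numbers. Given that modest step, only a small downward shift in this assay is expected, probably none beyond the scatter. The expected change is a 1.4-fold lower number from compound 3 to compound 4 (0.15 log units; within the scatter). For compound 4 the estimated value is 7500 nM, within an expected range of 2800 nM to 20000 nM.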

Compound 4, concentration for 50% growth inhibition: 3420 nM
Beside the measured number, compound 4's estimate is 2.2-fold (0.34 log units) above it, within the range that was stated.
By their numbers in this assay, from the lowest: compounds 4 and 2 (each within the scatter of the next); then compound 3. At a limit, above all of these: compound 1.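

In this assay, pentan-3-yl on a saturated chain carbon bound to an oxygen on an aromatic ring gives a 3.1-fold lower number from compound 3 to compound 4 (0.49 log units; beyond the scatter), so this place accepts a larger branched group than isobutyl with no loss of growth inhibition. The step of a 1.0-fold lower number from compound 2 to compound 4 (0.00 log units; within the scatter) puts neopentyl and pentan-3-yl level, showing that two differently branched groups can serve equally here. The step of an at least 8.7-fold lower number from compound 1 to compound 4 (0.94 log units; beyond the scatter) gives only a bound, since compound 1 stands at a limit: the limit of > 30000 nM in this assay, at which 1 of the 4 values shown sits.

On these data alone, whether an amine, a carboxylic acid or a longer branched chain in place of pentan-3-yl would keep this level stays open in this assay.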